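A few compounds are considered here, and "the series" means these few. Any claim that something is new, unique, unknown or untested is made for them only; others in the source may bear on it.

Compound 3 `COc1cc(-c2nn(-c3cccc(NC(=O)Nc4ccc(Cl)c(Cl)c4)c3)cc2-c2ccncc2)ccc1Cl` gives 34200 nM in a functional assay on DU-145 cells (Homo sapiens) for inhibition, read by sulforhodamine B assay, with a stated time of 48 h; on this read-out lower numbers stand for stronger inhibition of growth and higher numbers for weaker inhibition of growth. Compound 2 `COc1cc(-c2nn(-c3cccc(NC(=O)c4cccc(C(F)(F)F)c4)c3)cc2-c2ccncc2)ccc1Cl` gives 32100 nM in this assay, and the step of a 1.1-fold higher number from compound 2 to compound 3 (0.03 log units; within the scatter) lies within the scatter. Compound 3 therefore sits level with compound 2. For compound 1 `O=C(Nc1cccc(-n2cc(-c3ccncc3)c(-c3ccc(Cl)c(O)c3)n2)c1)Nc1cccc(C(F)(F)F)c1` the assay reports only a limit, > 32500 nM (the limit of > 32500 nM in this assay, at which 1 of the 3 values shown sits). Compound 4 `O=C(Nc1cccc(-n2cc(-c3ccncc3)c(-c3ccc(Cl)c(O)c3)n2)c1)Nc1ccc(Cl)c(Cl)c1` differs from compound 3 by hydrogen in place of methyl on an oxygen on an aromatic ring, that is methoxy to hydroxy, 4-chloro-3-methoxyphenyl to 4-chloro-3-hydroxyphenyl. Among the compounds with values here, no measured step isolates this change: compound 1 and compound 2 differ in this place and also on the carbonyl carbon, so their values show only that both sit near the limit. The step of a 1.0-fold higher number from compound 3 to compound 4 (0.01 log units; within the scatter) is thus expected to be none beyond the scatter. Compound 4 is estimated at 35000 nM in this assay, within 16000 nM to 75000 nM.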

Compound 4, concentration for total growth inhibition: > 32500 nM
Compound 4: only a limit was reported; the forecaster's own chance of this, stated with the estimate: 45%; the middle value is on the limit's open side.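

Within the data shown here, compound 4 gives only a limit, > 32500 nM, in this assay, so no step from compound 3 or compound 1 to compound 4 can be read: the limit of > 32500 nM in this assay, at which 2 of the 4 values shown sit.

On these data alone, what the change from methoxy to hydroxy does on its own stays open.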